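This account rests on a few compounds, and the source may have more. Where it says the series, first, only, none or still open, it means among the compounds named here.

Working notes on the series. In a functional assay on CEM-SS cells (Homo sapiens) for cytotoxicity (on this read-out higher numbers stand for weaker inhibition and lower numbers for stronger inhibition), compound 1 (`Cc1cccc(Cn2c(N)nc3cc(Cl)c(Cl)cc32)c1`) gives 48000 nM, compound 2 (`Nc1nc2cc(Cl)c(Cl)cc2n1Cc1cccc(C(F)(F)F)c1`) gives 34000 nM and compound 3 (`Nc1nc2cc(Cl)c(Cl)cc2n1Cc1cc(C(F)(F)F)cc(C(F)(F)F)c1`) gives 17000 nM. On these numbers compound 2 cannot be separated from either of the other two. Replacing methyl with trifluoromethyl on an aromatic carbon gives a 1.4-fold lower number from compound 1 to compound 2 (0.15 log units; within the scatter). Adding trifluoromethyl in place of hydrogen on an aromatic carbon gives a 2.0-fold lower number from compound 2 to compound 3 (0.30 log units; within the scatter).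

The next comparison is with compound 4 (`FC(F)(F)c1cccc(Cn2c(Cl)nc3cc(Cl)c(Cl)cc32)c1`). The change is chloro in place of amino on an aromatic carbon, at the place between two ring nitrogen atoms. Among the measured compounds shown here, neither measured step alters the amino group, so the series offers no direct precedent for this change. The two steps bear on it only indirectly, as a sign that the numbers in this assay have stayed close across the changes made so far. On these data alone, on that limited basis, no step beyond the scatter is expected, and the direction remains open. The expected change is a 1.2-fold lower number from compound 2 to compound 4 (0.08 log units; within the scatter). For compound 4 the estimated value is 28000 nM, with an expected range of 10000 nM to 75000 nM.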

Compound 4, half-maximal inhibitory concentration: > 100000 nM
Compound 4: only a limit was reported; the forecaster's own chance of this, stated with the estimate: 15%; middle value at least 3.5-fold (0.55 log units) from the limit.
By their numbers in this assay, from the lowest: compounds 3, 2 and 1 (each within the scatter of the next, the first and the last beyond it). At a limit, above all of these: compound 4.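

Chloro in place of amino, at the place between two ring nitrogen atoms, gives an at least 2.9-fold higher number from compound 2 to compound 4 (0.46 log units; beyond the scatter), the only step in the series so far that lies beyond the scatter, whereas the two trifluoromethyl steps stayed within it. Among the compounds shown here, this place therefore responds to change in this assay in a way that the earlier compounds, all of which keep the amino group, could not show, and the direction is toward weaker inhibition. The full size of the step cannot be read, since compound 4 carries only a limit and not a number: the limit of > 100000 nM in this assay, at which 1 of the 4 values shown sits.

With a single replacement at this place, the compounds shown do not separate the loss of amino from the entry of chloro, and a methylamino group, a hydroxyl group or plain hydrogen at the same place would bear on that question. On these data alone, it also remains open whether the same replacement would give a step of similar direction on the background of compound 3, with its two trifluoromethyl groups, or of compound 1, with its methyl group.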